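Mirror-image oxetanone urea: an estimate for compound 4

This account rests on a few compounds, and the source may have more. Where it says the series, first, only, none or still open, it means among the compounds named here.

Measured compounds:
Compound 1, `O=C(NC1CCC1)OCc1ccccc1`, gives > 100000 nM in an assay on HEK293 cells for inhibition of N-acylethanolamine-hydrolyzing acid amidase (Rattus norvegicus), read by LC-MS, with a stated time of 30 min (a higher number here means a weaker inhibitor, a lower number a stronger inhibitor), which is a limit of the assay.
Compound 2, `O=C(NC1CCC1=O)OCc1ccccc1`, gives > 100000 nM in this assay, again a limit.
Compound 3, `O=C(NCc1ccccc1)N[C@H]1COC1=O`, gives 15000 nM in this assay.

Among the measured compounds shown here, compound 3 is therefore the only one of the three with a number rather than a limit, and it stands alone as the one compound showing measurable inhibition. The unmeasured compound 4, `O=C(NCc1ccccc1)N[C@@H]1COC1=O`, differs from compound 3 as follows: the two compounds have the same atoms and bonds and differ only in configuration as drawn: 1 of 1 stereo elements differ; a stereocentre at a saturated ring carbon is drawn S in compound 3 and R in compound 4. For the measured compounds named here, no measured step involves a change of configuration. Going by the values given here, the one measured step, a step that the two limits leave unreadable from compound 1 to compound 2, is unreadable because of the limit of > 100000 nM in this assay, at which 2 of the 3 values shown sit, so it gives no guidance on size or direction. The expectation for compound 4 thus rests on the value of compound 3 alone and on the fact that only its configuration is altered. Compound 4 is expected at 60000 nM, within 15000 nM to 200000 nM. This corresponds to an expected step of a 4.0-fold higher number from compound 3 to compound 4 (0.60 log units; beyond the scatter), a loss of potency that is uncertain in size.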

Compound 4, half-maximal inhibitory concentration: 49200 nM
Compound 4: middle estimate off by 1.2-fold (0.09 log units), on the high side; the range from low to high includes it.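

In this assay, the configuration at this saturated ring carbon matters on its own, as the change from S to R gives a 3.3-fold higher number from compound 3 to compound 4 (0.52 log units; beyond the scatter). Among the compounds shown here, the earlier compounds could not show the size of any change, since their only step cannot be read: the limit of > 100000 nM in this assay, at which 2 of the 4 values shown sit. The difference between these two compounds can be assigned to the stereocentre alone: the fact that compounds 3 and 4 differ only in the configuration as drawn.

As far as these compounds go, it remains open whether S would still give the lower number if a longer chain, such as phenylbutyl, took the place of benzyl on the urea. From the compounds shown here alone, it is also open whether the same difference between S and R would appear if a carbamate linkage, as in compound 1, took the place of the urea on the oxetanone.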